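A few compounds are considered here, and "the series" means these few. Any claim that something is new, unique, unknown or untested is made for them only; others in the source may bear on it.

Compound 2 `CCCCOc1nccnc1C1CN2CCC1CC2` gives 15% in a functional assay on A9L-m1 cells with A9 (Mus musculus) as the target (on this read-out lower numbers stand for smaller maximal responses and higher numbers for larger maximal responses), and it stands alongside compound 1 `Clc1nccnc1C1CN2CCC1CC2`, which gives 13%, the two numbers lying within the scatter of each other. Among the compounds with values here, the only recorded step between them is a number 2 percentage points higher from compound 1 to compound 2 (within the scatter). Compound 3 `CCCCCOc1nccnc1C1CN2CCC1CC2` differs from compound 2 by methyl in place of hydrogen on a saturated chain carbon, four bonds along the chain from an oxygen on an aromatic ring. Within the data shown here, no measured step adds a methyl on a saturated chain carbon, so the butoxy-for-chloro step is the nearest comparison, and it stayed within the scatter. Compound 3 is therefore expected to give 15%, between 5% and 28%, a step of no change at the digits printed from compound 2 to compound 3 (within the scatter) expected to remain within the scatter.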

Compound 3, largest response reached (reported as maximum), in percent of the reference or control that the assay uses: 32%
Compound 3: the middle estimate sits 17 percentage points below what was measured; the measured number lies above the stated range.
By their numbers in this assay, from the lowest: compounds 1 and 2 (each within the scatter of the next); then compound 3.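

In this assay, extending butoxy to pentyloxy gives a number 17 percentage points higher from compound 2 to compound 3 (beyond the scatter) in this series, so a single methyl on the saturated chain carbon, four bonds along the chain from an oxygen on an aromatic ring, can move the maximal response. Pentyloxy in place of chloro likewise gives a number 19 percentage points higher from compound 1 to compound 3 (beyond the scatter) here, whereas butoxy had stayed within the scatter of chloro. Nothing available accounts for this rise.

As far as these compounds go, whether hexyloxy would continue the rise stays open, as a single step of this kind shows no trend. Also open, from the compounds shown here alone, is how an amine or a carboxylic acid at the end of the chain would compare.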